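A few compounds are considered here, and "the series" means these few. Any claim that something is new, unique, unknown or untested is made for them only; others in the source may bear on it.

Measured in an ADME assay on MDCKII-LE cells (Canis lupus familiaris) for permeability; a lower number here means that the compound crosses the layer more slowly, a higher number that the compound crosses the layer faster:
compound 1 `O=C(O)c1ccc(NC(=O)[C@H](CC2CCCC2)n2cnc(S(=O)(=O)C3CC3)c2)nc1` gives 0.6 10^-6 cm/s
compound 2 `O=C(O)c1ccc(NC(=O)[C@H](CC2CCCC2)n2cnc(S(=O)(=O)C3CCC3)c2)nc1` gives 0.5 10^-6 cm/s
compound 3 `O=C(O)c1ccc(NC(=O)[C@H](CC2CCOCC2)n2cnc(S(=O)(=O)C3CC3)c2)nc1` gives 0.9 10^-6 cm/s

All three numbers lie within the usual scatter of one another, so no order among compounds 1, 2 and 3 is claimed. Compound 2 differs from compound 1 by cyclobutyl in place of cyclopropyl on a sulfonyl sulfur; the step is a 1.2-fold lower number from compound 1 to compound 2 (0.08 log units; within the scatter). Compound 3 differs from compound 1 by oxan-4-yl in place of cyclopentyl on a saturated chain carbon, two bonds along the chain from an aromatic nitrogen and a carbonyl carbon; that step is a 1.5-fold higher number from compound 1 to compound 3 (0.18 log units; within the scatter).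

Compound 4 `O=C(O)c1ccc(NC(=O)[C@H](CC2CCOCC2)n2cnc(S(=O)(=O)C3CCC3)c2)nc1` has not yet been measured in this assay. It differs from compound 3 by cyclobutyl in place of cyclopropyl on a sulfonyl sulfur. This is the same change as from compound 1 to compound 2, at the same place word for word, and it occurs twice among these four compounds; the two cores differ as described for compound 3 against compound 1.

Within the data shown here, the only guide is the earlier step, a 1.2-fold lower number from compound 1 to compound 2 (0.08 log units; within the scatter), which stayed within the scatter. For compound 4 the step is therefore expected to be of similar size, a 1.1-fold lower number from compound 3 to compound 4 (0.05 log units; within the scatter), resting on that single earlier pair. Compound 4 is thus estimated at 0.8 10^-6 cm/s, with a range from 0.4 10^-6 cm/s to 1.5 10^-6 cm/s.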

Compound 4, apparent permeability: 0.9 10^-6 cm/s
The estimate for compound 4 lay 1.1-fold (0.05 log units) below the measured number, and the stated range covers the measured number.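

In this assay, cyclobutyl in place of cyclopropyl on a sulfonyl sulfur gives no change at the digits printed from compound 3 to compound 4 (within the scatter), and this change reads alike on the two cores: the same change on two cores in this assay, a 1.2-fold lower number (0.08 log units; within the scatter) from compound 1 to compound 2 and no change at the digits printed (within the scatter) from compound 3 to compound 4, 1.2-fold (0.08 log units) apart, within the scatter of two such steps. Oxan-4-yl in place of cyclopentyl gives a 1.8-fold higher number from compound 2 to compound 4 (0.26 log units; within the scatter), and this change also reads alike with either sulfonyl group present: the same change on two cores in this assay, a 1.5-fold higher number (0.18 log units; within the scatter) from compound 1 to compound 3 and a 1.8-fold higher number (0.26 log units; within the scatter) from compound 2 to compound 4, 1.2-fold (0.08 log units) apart, within the scatter of two such steps. Among these compounds, all four steps stay within the scatter, so these four compounds show only that neither change gave a measurable step on either core; they do not show how a step of real size would carry from one core to another, and they support no rule beyond this set.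

Still open, as far as these compounds go, is whether an amine on the group at the sulfonyl sulfur, or a longer chain in place of cyclobutyl, would give a step beyond the scatter. From the compounds shown here alone, how the number responds to an amide in place of the carboxylic acid shared by all four compounds also remains open.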